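Swapping Ethyl for Trifluoromethyl on a Shared Core

The compounds below may be only part of what the source reports. "The series", "measured", "known", "first", "only" and "open" are said of these compounds alone.

Compound 1 `CCc1cccc(C[C@H](O)/C=C/[C@H]2COC(=O)N2CCSCCCC(=O)O)c1` was measured in an assay on CHO cells for displacement of a labelled ligand from prostaglandin E2 receptor EP2 subtype (Mus musculus), read by scintillation counting, with a stated time of 60 min (a higher number here means a weaker inhibitor, a lower number a stronger inhibitor), and gives > 10000 nM there, which is a limit of the assay rather than a number. Compound 2 `CCCc1cccc(C[C@H](O)/C=C/[C@H]2CSC(=O)N2CCSCCCC(=O)O)c1` gives > 10000 nM in this assay, also a limit. Compound 3 `COCc1cccc(C[C@H](O)/C=C/[C@H]2CSC(=O)N2CCSCCCC(=O)O)c1` gives > 10000 nM in this assay, again a limit. For the measured compounds named here, the only comparison between measured compounds is a step that the two limits leave unreadable from compound 2 to compound 3 in this assay. Compound 1 thus stands where the limit of > 10000 nM in this assay, at which 3 of the 3 values shown sit, is found. Compound 4 `O=C(O)CCCSCCN1C(=O)OC[C@@H]1/C=C/[C@@H](O)Cc1cccc(C(F)(F)F)c1` differs from compound 1 in one place: trifluoromethyl in place of ethyl on an aromatic carbon on the shared core. No readable step covers this change, so no direction beyond the scatter can be expected. Compound 4 is estimated at 20000 nM in this assay, between 5000 nM and 100000 nM in range. That estimate means an expected step that the limit leaves unreadable from compound 1 to compound 4 in this assay.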

Compound 4, inhibition constant: > 10000 nM
Compound 4: no number, only a limit; the forecaster's own chance of this, stated with the estimate: 85%; the middle value lies beyond the limit too.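

For the compounds shown here, compound 1 and compound 4 each give only a limit, not a number, so no step between them can be read. The compounds shown leave open how strong an inhibitor any of them is in this assay, and whether trifluoromethyl in place of ethyl changes that at all.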